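The source may report more compounds than this note shows. Statements on the series, on what has been measured and on what is new or still open speak of the compounds shown alone.

Of the compounds shown here, two sharing one core have been measured in an assay on HEK293 cells for binding affinity to Substance-K receptor (Rattus norvegicus), read by FRET, tested at 10 uM; on this read-out lower numbers stand for less inhibition and higher numbers for more inhibition at the one concentration tested (going by the name of the read-out). Compound 1 `N#CCN(Cc1ccccc1)Cc1ccc2ccccc2c1` gives 0% in this assay. Compound 2 `N#CCN(Cc1ccc(CCc2ccccc2)cc1)Cc1ccc2ccccc2c1` gives 20% in this assay, the higher of the two numbers and the only one above the baseline of compound 1. Among the measured compounds shown here, the single measured step, a number 20 percentage points higher from compound 1 to compound 2 (beyond the scatter), came with phenethyl in place of hydrogen on an aromatic carbon. Compound 3 `COc1ccc(CN(CC#N)Cc2ccc3ccccc3c2)cc1` has not yet been measured in this assay; it differs from compound 2 in one place, (methoxy in place of phenethyl on an aromatic carbon). For the measured compounds named here, the only measured step that bears on this change is a number 20 percentage points higher from compound 1 to compound 2 (beyond the scatter), the gain seen when phenethyl entered; with phenethyl leaving again and methoxy standing in its place, a downward step of a number 15 percentage points lower from compound 2 to compound 3 (beyond the scatter) is expected, giving back most of that gain. For compound 3 the value expected in this assay is 5%, with a range from -10% to 20%.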

Compound 3, a percentage reported as inhibition, at one concentration (the size of the read-out at that concentration, not a potency): 0%
Compound 3: middle estimate off by 5 percentage points, on the high side, within the range that was stated.
By their numbers in this assay, from the lowest: compounds 1 and 3 (each within the scatter of the next); then compound 2.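

In this assay, methoxy in place of phenethyl on this aromatic carbon gives a number 20 percentage points lower from compound 2 to compound 3 (beyond the scatter). Set against hydrogen at the same place, methoxy gives no change at the digits printed from compound 1 to compound 3 (within the scatter), so this small oxygen-bearing group cannot be told apart from hydrogen here. Among the compounds shown here, the earlier pair showed only that phenethyl raised the number; this result shows that the rise does not come with just any group at this position, since of the three groups seen here only phenethyl stands apart.

Nothing available explains why phenethyl differs from methoxy. As far as these compounds go, whether a butyl chain, a phenoxy group or an amine at this position would match phenethyl or match hydrogen stays open, and so does whether the ring of phenethyl or its length is what counts.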